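Chloro entering the trifluoromethylphenyl urea of compound 1

The source may report more compounds than this note shows. Statements on the series, on what has been measured and on what is new or still open speak of the compounds shown alone.

Compound 1 `O=C(Nc1cccc(-n2cc(-c3ccncc3)c(-c3ccc(Cl)c(O)c3)n2)c1)Nc1cccc(C(F)(F)F)c1` gives only a limit of the assay, > 32500 nM, in a functional assay on Hs-578T cells (Homo sapiens) for inhibition, read by sulforhodamine B assay, with a stated time of 48 h; on this read-out higher numbers stand for weaker inhibition of growth and lower numbers for stronger inhibition of growth; it sits at the limit of > 32500 nM in this assay, at which 1 of the 2 values shown sits. Compound 2 `COc1cc(-c2nn(-c3cccc(NC(=O)Nc4cccc(C(F)(F)F)c4)c3)cc2-c2ccncc2)ccc1Cl` reaches 12500 nM in this assay. Going by the values given here, the one measured step, an at least 2.6-fold lower number from compound 1 to compound 2 (0.41 log units; beyond the scatter), concerns the oxygen on the other aromatic ring and does not touch the place changed here. Compound 3 `O=C(Nc1cccc(-n2cc(-c3ccncc3)c(-c3ccc(Cl)c(O)c3)n2)c1)Nc1ccc(Cl)c(C(F)(F)F)c1` differs from compound 1 by chloro in place of hydrogen on an aromatic carbon. Among the compounds with values here, no measured step bears on this change, so no step beyond the scatter is expected in either direction, and the estimated step of a number no higher from compound 1 to compound 3 (the limit leaves the size open) is set near nothing. Compound 3 is expected at 32500 nM, between 9000 nM and 80000 nM, most likely again only a limit.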

Compound 3, concentration for total growth inhibition: 11200 nM
Estimate against measurement, compound 3: 2.9-fold (0.46 log units) above; the measured number falls inside the stated range.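

In this assay the change from 3-(trifluoromethyl)phenyl to 4-chloro-3-(trifluoromethyl)phenyl gives an at least 2.9-fold lower number from compound 1 to compound 3 (0.46 log units; beyond the scatter) and so shows that the urea aryl ring, untouched by the earlier step, also responds to substitution. Compound 1 stands as a limit of the assay, so the full size of this step stays unread: the limit of > 32500 nM in this assay, at which 1 of the 3 values shown sits.

From the compounds shown here alone, whether chloro gives a like step on compound 2, with its methoxy group, remains open. Also open, going by these compounds, is whether methyl, methoxy or an amine on this same carbon would match chloro.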